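Swapping a Para Group on the Pendant Phenyl Ring

A few compounds are considered here, and "the series" means these few. Any claim that something is new, unique, unknown or untested is made for them only; others in the source may bear on it.

Of the compounds shown here, three built on one shared core have been tested in a functional assay on MKN-45 cells (Homo sapiens) for cytotoxicity, read by MTT assay, with a stated time of 72 h; on this read-out lower numbers stand for stronger inhibition and higher numbers for weaker inhibition. Compound 1 `COc1cc2c(Oc3ccc(NC(=O)c4cc(-c5ccc(F)cc5)ccn4)cc3F)ccnc2cc1OCCCN1CCCCC1` gives 1240 nM in this assay. Compound 2 `COc1cc2c(Oc3ccc(NC(=O)c4cc(-c5ccccc5F)ccn4)cc3F)ccnc2cc1OCCCN1CCCCC1` gives 180 nM in this assay. Compound 3 `COc1cc2c(Oc3ccc(NC(=O)c4cc(-c5ccc(C(F)(F)F)cc5)ccn4)cc3F)ccnc2cc1OCCCN1CCCCC1` gives 870 nM in this assay, the second highest of the three numbers: a 1.4-fold lower number from compound 1 to compound 3 (0.15 log units; within the scatter) lies within the scatter, while a 4.8-fold higher number from compound 2 to compound 3 (0.68 log units; beyond the scatter) lies beyond it. Compound 4 `COc1ccc(-c2ccnc(C(=O)Nc3ccc(Oc4ccnc5cc(OCCCN6CCCCC6)c(OC)cc45)c(F)c3)c2)cc1` has not yet been measured. It differs from compound 3 in a single place: methoxy in place of trifluoromethyl on an aromatic carbon. Within the data shown here, the one measured step that changes a group at the same place is a 1.4-fold lower number from compound 1 to compound 3 (0.15 log units; within the scatter), which stayed within the scatter. The steps of a 6.9-fold lower number from compound 1 to compound 2 (0.84 log units; beyond the scatter) and a 4.8-fold higher number from compound 2 to compound 3 (0.68 log units; beyond the scatter) each exchange one fluorophenyl isomer for another and so bear less directly on this change. Since exchanging one group for another at this place moved the number little, the expected step is a 1.0-fold higher number from compound 3 to compound 4 (0.01 log units; within the scatter), not clearly beyond the scatter. The estimate for compound 4 in this assay is 900 nM, in the range 350 nM to 2500 nM.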

Compound 4, half-maximal inhibitory concentration: 570 nM
Beside the measured number, compound 4's estimate is 1.6-fold (0.20 log units) above it, within the range that was stated.
By their numbers in this assay, from the lowest: compound 2; then compounds 4, 3 and 1 (each within the scatter of the next, the first and the last beyond it).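

In this assay the change from trifluoromethyl to methoxy gives a 1.5-fold lower number from compound 3 to compound 4 (0.18 log units; within the scatter) and so, even with a hydrogen-bond acceptor entering, the number does not clearly move. Among these compounds, measured against fluoro, however, methoxy gives a 2.2-fold lower number from compound 1 to compound 4 (0.34 log units; beyond the scatter) and this is the first exchange at this place to pass the scatter, although only modestly. The 2-fluorophenyl group of compound 2 still holds the lowest number of the four, as a 3.2-fold higher number from compound 2 to compound 4 (0.50 log units; beyond the scatter) shows, so methoxy narrows that gap without closing it.

On these data alone, whether an amine or a carboxylic acid at this same place would move the number further, and whether 2-methoxyphenyl would match 2-fluorophenyl, stays open. Nothing available here accounts for any of these differences.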